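The source may hold more compounds than are shown below. What is called first, only, known or untested is meant among the compounds shown, and "the series" means these compounds.

Measured in an ADME assay on MRC5 cells (Homo sapiens) for inhibition, with a stated time of 72 h; on this read-out higher numbers stand for an effect only at larger amounts of compound and lower numbers for an effect already at smaller amounts:
- compound 1 `COc1cccc(OC)c1C(=O)Nc1c[nH]nc1C(=O)N[C@H]1CC[C@H](OC)CC1`: 31000 nM
- compound 2 `CCc1ccccc1C(=O)Nc1c[nH]nc1C(=O)N[C@H]1CC[C@H](OC)CC1`: 3400 nM
- compound 3 `CO[C@H]1CC[C@H](NC(=O)c2n[nH]cc2NC(=O)c2ccc(F)cc2F)CC1`: 11000 nM

Compound 3 holds the second highest of the three numbers, with compound 1 higher and compound 2 lower, both gaps beyond the scatter. Compound 4 `COc1ccccc1C(=O)Nc1c[nH]nc1C(=O)N[C@H]1CC[C@H](OC)CC1` is the next to consider: 2-methoxyphenyl in place of 2,4-difluorophenyl on a carbonyl carbon. For the measured compounds named here, one measured step bears on this place, a 3.2-fold higher number from compound 2 to compound 3 (0.51 log units; beyond the scatter), which is modest. Going by the values given here, no measured step shows the 2-methoxyphenyl group itself, so no step beyond the scatter is expected in this assay. The expected change is a 1.2-fold lower number from compound 3 to compound 4 (0.09 log units; within the scatter). For compound 4 the estimated value is 9000 nM, with an expected range of 3500 nM to 25000 nM.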

Compound 4, half-maximal effective concentration: 1500 nM
Beside the measured number, compound 4's estimate is 6.0-fold (0.78 log units) above it; measured number outside the range, below it.
By their numbers in this assay, from the lowest: compound 4; then compound 2; then compound 3; then compound 1.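

In this assay, for the compounds shown here, the aryl group on this carbonyl carbon carries more weight than the earlier compounds showed, with a 7.3-fold lower number from compound 3 to compound 4 (0.87 log units; beyond the scatter) and, for methoxy in place of ethyl, a 2.3-fold lower number from compound 2 to compound 4 (0.36 log units; beyond the scatter), leaving compound 4 with the lowest number of the four. A methoxy group alone does not secure a low number, since hydrogen in place of the other methoxy gives a 21-fold lower number from compound 1 to compound 4 (1.32 log units; beyond the scatter). No measurement on hand accounts for these steps.

Open, as far as these compounds go, is how an amine, a carboxylic acid or a longer alkoxy chain would behave in place of this methoxy. Also open, from the compounds shown here alone, is whether these steps would hold on a different core.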